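The compounds below may be only part of what the source reports. "The series", "measured", "known", "first", "only" and "open" are said of these compounds alone.

In a functional assay on HeLa cells (Homo sapiens) for inhibition (on this read-out higher numbers stand for weaker inhibition and lower numbers for stronger inhibition), compound 1 `CCCCCCCCCCCCCCCCCCOC[C@H](COP(=O)(O)O[C@H]1[C@@H](O)[C@@H](O)[C@H](O)C[C@H]1O)OC` gives 7000 nM. Compound 2 `CCCCCCCCCCCCCCCCCCOC[C@H](COP(=O)(O)O[C@@H]1[C@H](O)[C@@H](CO)[C@@H](O)[C@H](O)[C@@H]1O)OC` gives 7500 nM, which places it level with compound 1 within the usual scatter. Compound 3 `CCCCCCCCCCCCCCCCCCOC[C@H](COP(=O)(O)O[C@@H]1[C@H](O)[C@H](CO)[C@@H](O)[C@H](O)[C@@H]1O)OC` has not yet been measured. Its relation to compound 2 is this: the two compounds have the same atoms and bonds; at least one stereo element is drawn with a configuration in one of them and without one in the other: 1 of 8 stereo elements differ; a stereocentre at a saturated ring carbon is drawn S in compound 2 and R in compound 3. A stereocentre at a saturated ring carbon is drawn S in compound 2 and R in compound 3. Among the compounds with values here, only one measured step is available, a 1.1-fold higher number from compound 1 to compound 2 (0.03 log units; within the scatter), with hydroxymethyl in place of hydrogen on a saturated ring carbon, and it stays within the scatter. Within the data shown here, that step changes a group and not a configuration, so it bears only indirectly on this pair, and no measured pair shows what a change of configuration does here. No shift beyond the scatter is therefore expected in this assay, and the expected step is no change at the digits printed from compound 2 to compound 3 (within the scatter). Compound 3 is estimated at 7500 nM, with an expected range of 3000 nM to 20000 nM.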

Compound 3, half-maximal inhibitory concentration: 1000 nM
Beside the measured number, compound 3's estimate is 7.5-fold (0.88 log units) above it; the whole stated range lies above it.
By their numbers in this assay, from the lowest: compound 3; then compounds 1 and 2 (each within the scatter of the next).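

Configuration at this saturated ring carbon matters in this assay, which the earlier pair could not show: the step is a 7.5-fold lower number from compound 2 to compound 3 (0.88 log units; beyond the scatter), with no atom or bond changed. Hydroxymethyl in place of hydrogen therefore no longer looks neutral, since one configuration gives a 7.0-fold lower number from compound 1 to compound 3 (0.85 log units; beyond the scatter), whereas the other gave a 1.1-fold higher number from compound 1 to compound 2 (0.03 log units; within the scatter). The gain in inhibition thus depends on the hydroxymethyl and its configuration together, and the one structural point that bears on the step is this: the fact that one of compounds 2 and 3 is drawn with a defined configuration and the other without, at the place where they differ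

The compounds shown leave open whether an aminomethyl group or a carboxylic acid on the same carbon would show a similar dependence on configuration. They also leave open whether a methyl group there would keep any of the gain seen with hydroxymethyl in compound 3.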